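A few compounds are considered here, and "the series" means these few. Any claim that something is new, unique, unknown or untested is made for them only; others in the source may bear on it.

Measured compounds:
compound 1, `CCOc1cc2[nH]c(Cc3nn(CC(=O)N4CCOCC4)c(=O)c4ccccc34)nc2cc1Cl`, 10 nM in a functional assay on CHO cells for antagonist activity at sphingosine 1-phosphate receptor 2 (Homo sapiens), read by calcium flux; a lower number here means a stronger inhibitor, a higher number a weaker inhibitor
compound 2, `O=C(O)Cn1nc(Cc2nc3cc(Cl)c(OC(F)(F)F)cc3[nH]2)c2ccccc2c1=O`, 31 nM in this assay

Of the two numbers, compound 2 carries the higher one. The gap between compound 2 and compound 1 lies beyond the usual scatter of repeated measurements; compound 1 is the stronger inhibitor of the pair. Going by the values given here, the two compounds differ in more than one place, so no single step between them can be read off.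

Compound 3, `CCOc1cc2[nH]c(Cc3nn(CC(=O)O)c(=O)c4ccccc34)nc2cc1Cl`, has not yet been tested in this assay. It is made from compound 2 by one change: ethyl in place of trifluoromethyl on an oxygen on an aromatic ring. The shared core, the acid-bearing chain and the chlorine stay as they are. Compound 1, which carries the same ethoxy group, gives 10 nM and points toward a lower number. A modest step down is therefore expected for compound 3, a 2.1-fold lower number from compound 2 to compound 3 (0.32 log units; beyond the scatter), likely beyond the scatter but not large. Compound 3 is estimated at 15 nM, with a range from 5 nM to 45 nM.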

Compound 3, half-maximal inhibitory concentration: 17 nM
Compound 3: the middle estimate sits 1.1-fold (0.05 log units) below what was measured, and the stated range covers the measured number.
By their numbers in this assay, from the lowest: compounds 1, 3 and 2 (each within the scatter of the next, the first and the last beyond it).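

In this assay, ethyl in place of trifluoromethyl on an oxygen on an aromatic ring gives a 1.8-fold lower number from compound 2 to compound 3 (0.26 log units; within the scatter), so with the acid-bearing chain held constant, the trifluoromethoxy and ethoxy compounds cannot be told apart. Going by these compounds alone, compound 3 also allows the chain to be read in one step for the first time: hydroxy in place of morpholin-4-yl on a carbonyl carbon gives a 1.7-fold higher number from compound 1 to compound 3 (0.23 log units; within the scatter), so the carboxylic acid and the morpholine amide cannot be told apart on the ethoxy compound either. Nothing available bears on why either step comes out as it does.

On these data alone, it remains open whether a methyl or a longer propyl chain on that oxygen would separate from ethyl. As far as these compounds go, it is equally open whether a simple primary amide or a piperazine amide in place of the morpholine amide would separate from the carboxylic acid.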